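The source may report more compounds than this note shows. Statements on the series, on what has been measured and on what is new or still open speak of the compounds shown alone.

Compound 1 `O=C(Cn1cc(-c2ccncc2)nn1)Nc1nccs1`: 2 nM
Compound 2 `O=C(Cn1cc(-c2cccc(Cl)c2)nn1)Nc1nccs1`: > 30000 nM

Going by the values given here, in a functional assay on BMDM cells (Mus musculus, strain C57BL/6) for inhibition, with a stated time of 2 days (a lower number here means a stronger inhibitor, a higher number a weaker inhibitor), compound 1 gives 2 nM, the only actual number among the two measured compounds. Compound 2 sits at the limit of > 30000 nM in this assay, at which 1 of the 2 values shown sits, which is a limit of the measurement and not a number. Among the compounds with values here, the one measured step, an at least 15000-fold higher number from compound 1 to compound 2 (4.17 log units; beyond the scatter), changes a group on an aromatic carbon, so it does not speak to the change that leads to compound 3 `Cc1cc(NC(=O)Cn2cc(-c3ccncc3)nn2)no1`: 5-methyl-1,2-oxazol-3-yl in place of 1,3-thiazol-2-yl on an amide-type nitrogen. Within the data shown here, with no measured step covering the amide-type nitrogen, only a modest change is expected, a 5.0-fold higher number from compound 1 to compound 3 (0.70 log units; beyond the scatter). Compound 3 is therefore estimated to give about 10 nM, somewhere between 2 nM and 100 nM.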

Compound 3, half-maximal inhibitory concentration: 430 nM
Compound 3: the middle estimate sits 43-fold (1.63 log units) below what was measured; the whole stated range lies below it.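

In this assay, the group on the amide-type nitrogen matters a great deal: 5-methyl-1,2-oxazol-3-yl in place of 1,3-thiazol-2-yl gives a 220-fold higher number from compound 1 to compound 3 (2.33 log units; beyond the scatter). The earlier step covered only the group on an aromatic carbon, so a large change now appears at a second place in the shared core, even though both groups are five-membered aromatic rings with the same counts of donors and acceptors. Nothing shown accounts for the size of this step.

The compounds shown do not separate the effect of the methyl from that of the ring. A plain 1,2-oxazol-3-yl group or a 5-methyl-1,3-thiazol-2-yl group at this place would address that question.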